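The source may hold more compounds than are shown below. What is called first, only, known or untested is meant among the compounds shown, and "the series" means these compounds.

Working notes on the series in a functional assay on HeLa cells (Homo sapiens) for inhibition, read by MTT assay, with a stated time of 72 h; a higher number here means a weaker inhibitor, a lower number a stronger inhibitor. Compound 2 `COc1cc(NC(C)CCCNC(=O)Nc2ccc(F)cc2)c2ncccc2c1` gives 20000 nM, the lowest of the three numbers; compound 3 `COc1cc(NC(C)CCCNC(=O)Nc2cccc(O)c2)c2ncccc2c1` gives 48000 nM, and compound 1 `COc1cc(NC(C)CCCNC(=O)NNC(=O)Nc2ccc(Cl)cc2)c2ncccc2c1` gives 120000 nM. Compound 4 `COc1cc(NC(C)CCCNC(=O)NNC(=O)Nc2ccc(O)cc2)c2ncccc2c1` is not yet measured and differs from compound 2 in one place: ((4-hydroxyphenyl)carbamoyl)amino in place of 4-fluorophenyl on an amide-type nitrogen. Within the data shown here, two measured steps bear on it. Read in reverse, a 6.0-fold lower number from compound 1 to compound 2 (0.78 log units; beyond the scatter) shows that the ((4-chlorophenyl)carbamoyl)amino linker costs a good deal against 4-fluorophenyl, and a 2.4-fold higher number from compound 2 to compound 3 (0.38 log units; beyond the scatter) shows a 3-hydroxyphenyl weaker than 4-fluorophenyl. Both point toward a higher number, while a 2.5-fold lower number from compound 1 to compound 3 (0.40 log units; beyond the scatter) suggests a hydroxyl may soften the rise somewhat. Compound 4 is therefore expected near 100000 nM, between 40000 nM and 250000 nM. The expected step is a 5.0-fold higher number from compound 2 to compound 4 (0.70 log units; beyond the scatter).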

Compound 4, half-maximal inhibitory concentration: 85000 nM
Estimate against measurement, compound 4: 1.2-fold (0.07 log units) above, within the range that was stated.
By their numbers in this assay, from the lowest: compound 2; then compounds 3, 4 and 1 (each within the scatter of the next, the first and the last beyond it).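

In this assay the change to ((4-hydroxyphenyl)carbamoyl)amino on the amide-type nitrogen gives a 4.3-fold higher number from compound 2 to compound 4 (0.63 log units; beyond the scatter) and so still costs against 4-fluorophenyl when the ring carries hydroxy rather than chloro. Hydroxy in place of chloro on an aromatic carbon gives a 1.4-fold lower number from compound 1 to compound 4 (0.15 log units; within the scatter) and does not separate that pair, and the comparison with 3-hydroxyphenyl gives a 1.8-fold higher number from compound 3 to compound 4 (0.25 log units; within the scatter) and does not separate that pair either. No measurement at hand explains these steps. Open, as far as these compounds go, is whether an amine or a carboxylic acid at that ring carbon would separate from hydroxy and chloro, and whether 4-fluorophenyl's advantage would survive a longer chain on the shared core.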